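Trading a tetrazole tail for a carboxylic acid

The source may report more compounds than this note shows. Statements on the series, on what has been measured and on what is new or still open speak of the compounds shown alone.

Of the compounds shown here, two have been measured in a functional assay (blood) for inhibition, with Homo sapiens as the target; a lower number here means a stronger inhibitor, a higher number a weaker inhibitor. Compound 1 `C/C(=N\OCCSc1nnnn1C)c1ccc(Sc2cc(F)cc(C3CCOCC3)c2)cc1` gives 120 nM in this assay. Compound 2 `CO[C@]1(c2cc(F)cc(S(=O)(=O)c3ccc(/C(C)=N/OCC#N)cc3)c2)CCO[C@@H](C)C1` gives 60 nM in this assay. Within the data shown here, of the two numbers measured, the one for compound 1 is the higher, yet the gap to compound 2 lies within the usual scatter of repeated measurements, so the two compounds cannot be told apart on this evidence.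

Compound 3 `C/C(=N\OCC(=O)O)c1ccc(Sc2cc(F)cc(C3CCOCC3)c2)cc1` has not been measured yet. It differs from compound 1 in one place: carboxy in place of ((1-methyl-1H-tetrazol-5-yl)sulfanyl)methyl on a saturated chain carbon bound to an oxygen. The shared core, the oxime ether and the diaryl sulfide are kept; only the end of the chain on the oxime oxygen changes.

Among the measured compounds shown here, no comparable pair of measured compounds exists here, so the size of this step has to be guessed. A carboxy group in place of the ((1-methyl-1H-tetrazol-5-yl)sulfanyl)methyl group is a large change in the part that is counted, and a modest weakening is expected, with the estimated step of a 1.8-fold higher number from compound 1 to compound 3 (0.26 log units; within the scatter) reaching somewhat beyond the scatter. Compound 3 is therefore estimated at 220 nM in this assay, within a range from 60 nM to 800 nM.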

Compound 3, half-maximal inhibitory concentration: 740 nM
Compound 3: middle estimate off by 3.4-fold (0.53 log units), on the low side; low and high end bracket the measured number.
By their numbers in this assay, from the lowest: compounds 2 and 1 (each within the scatter of the next); then compound 3.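

In this assay, the end of the chain on the oxime oxygen clearly matters: carboxy in place of ((1-methyl-1H-tetrazol-5-yl)sulfanyl)methyl gives a 6.2-fold higher number from compound 1 to compound 3 (0.79 log units; beyond the scatter), while the shared core stays the same. Among these compounds, this is the first view of what a change at this position does on its own, since the two earlier compounds differ in more than one place and could not isolate it. Several things differ in this single exchange, as the five-membered aromatic ring and the sulfur leave and a smaller group with a hydrogen-bond donor enters, and nothing measured here gives a reason for the step.

From the compounds shown here alone, it remains open which of these differences carries the step, and a methyl ester or a primary amide on the same chain, or a carboxy group on a longer chain, would help to separate them. Going by these compounds, whether the same exchange would give a step of similar size on a different core also remains open.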